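The source may hold more compounds than are shown below. What is called first, only, known or untested is meant among the compounds shown, and "the series" means these compounds.

Among the measured compounds shown here, in a functional assay on DU-145 cells (Homo sapiens) for inhibition, read by trypan blue exclusion, with a stated time of 96 h (a lower number here means a stronger inhibitor of growth, a higher number a weaker inhibitor of growth), compound 3 `O=C(/C(=C\c1ccc(Br)cc1)Sc1ccc(Br)cc1)c1ccc(Cl)cc1` gives 1000 nM, the lowest of the three numbers measured so far. Compound 2 `COc1ccccc1/C=C(/SCc1ccccc1F)C(=O)c1ccc(Cl)cc1` gives 10000 nM, and compound 1 `O=C(/C(=C\c1c(O)cc(O)cc1O)Sc1ccc(Br)cc1)c1ccc(Cl)cc1` gives 50000 nM. Compound 4 `COc1ccccc1/C=C(/Sc1ccc(Br)cc1)C(=O)c1ccc(Cl)cc1` has not yet been measured. It differs from compound 3 by one exchange: 2-methoxyphenyl in place of 4-bromophenyl on a double-bonded chain carbon bound to a double-bonded chain carbon.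

For the measured compounds named here, only one measured step changes the group at this same place: a 50-fold lower number from compound 1 to compound 3 (1.70 log units; beyond the scatter). That step is large and well beyond the scatter, so a change here can shift the number considerably. It does not, however, involve 2-methoxyphenyl. Compound 2 does carry 2-methoxyphenyl and gives 10000 nM, but it differs from compound 4 elsewhere in the structure, so it offers only a rough guide.

A smaller change than the measured step is expected, towards a weaker inhibitor of growth: a 3.0-fold higher number from compound 3 to compound 4 (0.48 log units; beyond the scatter). For compound 4 the estimated value is 3000 nM, with an expected range of 800 nM to 12000 nM.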

Compound 4, concentration for 50% growth inhibition: 10000 nM
The estimate for compound 4 lay 3.3-fold (0.52 log units) below the measured number; measured number inside the range.
By their numbers in this assay, from the lowest: compound 3; then compounds 2 and 4 (each within the scatter of the next); then compound 1.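

In this assay, 2-methoxyphenyl in place of 4-bromophenyl gives a 10-fold higher number from compound 3 to compound 4 (1.00 log units; beyond the scatter), so this position also responds to an exchange between two groups that carry no hydroxyl, not only to the removal of 2,4,6-trihydroxyphenyl. 2-Methoxyphenyl in place of 2,4,6-trihydroxyphenyl gives a 5.0-fold lower number from compound 1 to compound 4 (0.70 log units; beyond the scatter), which ranks the three groups at this position, from the lowest number: 4-bromophenyl, 2-methoxyphenyl, 2,4,6-trihydroxyphenyl. On the sulfur, 4-bromophenyl in place of 2-fluorobenzyl gives no change at the digits printed from compound 2 to compound 4 (within the scatter), and nothing measured here explains any of these differences.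

Going by these compounds, it remains open whether 2-fluorobenzyl on the sulfur would also match 4-bromophenyl there when the chain carbon carries 4-bromophenyl. On these data alone, it is also open how a phenyl ring bearing an amine or a carboxylic acid would compare at the chain carbon.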